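From Diisopropylamino to Pyrrolidin-1-yl: An Expected Step

The source may report more compounds than this note shows. Statements on the series, on what has been measured and on what is new or still open speak of the compounds shown alone.

Compound 1 `COC/C1=C/C[C@](C)(CCC=C(C)C)/C=C/[C@@H](OC(=O)C=C(C)C)[C@](C)(O)/C=C/C1=O`: 3950 nM
Compound 2 `CCN(CC)C/C1=C/C[C@](C)(CCC=C(C)C)/C=C/[C@@H](OC(=O)C=C(C)C)[C@](C)(O)/C=C/C1=O`: 130 nM
Compound 3 `CC(C)=CCC[C@]1(C)/C=C/[C@@H](OC(=O)C=C(C)C)[C@](C)(O)/C=C/C(=O)/C(CN(C(C)C)C(C)C)=C\C1`: 650 nM

All three values come from a functional assay on A549 cells (Homo sapiens) for antiproliferative activity, read by MTT assay, with a stated time of 48 h; a lower number here means a stronger inhibitor, a higher number a weaker inhibitor. Compound 3, at 650 nM, holds the middle place of the three numbers. Replacing methoxy with an amine lowered the number both times, with a 30-fold lower number from compound 1 to compound 2 (1.48 log units; beyond the scatter) for diethylamino and a 6.1-fold lower number from compound 1 to compound 3 (0.78 log units; beyond the scatter) for diisopropylamino. The two amines also differ from each other, with a 5.0-fold higher number from compound 2 to compound 3 (0.70 log units; beyond the scatter).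

The next compound is compound 4 `CC(C)=CCC[C@]1(C)/C=C/[C@@H](OC(=O)C=C(C)C)[C@](C)(O)/C=C/C(=O)/C(CN2CCCC2)=C\C1`, not yet measured. It carries pyrrolidin-1-yl in place of diisopropylamino on a saturated chain carbon bound to a double-bonded ring carbon. For the measured compounds named here, no measured compound has a ring amine at this place, so the amine steps above serve only as a loose guide. The closest of them is the step between the two amines, which is beyond the scatter and shows that the choice of amine can shift the number. Compound 2 is taken as the nearer model, and a move toward its value is expected.

The expected step is a 2.5-fold lower number from compound 3 to compound 4 (0.40 log units; beyond the scatter), which is modest and uncertain. For compound 4, the estimated value is 260 nM, with an expected range from 90 nM to 750 nM.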

Compound 4, half-maximal inhibitory concentration: 180 nM
The estimate for compound 4 lay 1.4-fold (0.16 log units) above the measured number; the measured number falls inside the stated range.
By their numbers in this assay, from the lowest: compounds 2 and 4 (each within the scatter of the next); then compound 3; then compound 1.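

The ring amine pyrrolidin-1-yl shows that the gain over methoxy at this place, on a saturated chain carbon bound to a double-bonded ring carbon, is not limited to open-chain amines: in this assay the change gives a 22-fold lower number from compound 1 to compound 4 (1.34 log units; beyond the scatter) and joins the earlier diethylamino and diisopropylamino steps in the same direction. Diisopropylamino now stands apart from both other amines, since pyrrolidin-1-yl in its place gives a 3.6-fold lower number from compound 3 to compound 4 (0.56 log units; beyond the scatter) and so adds a second amine that differs from it beyond the scatter, while the comparison with diethylamino gives a 1.4-fold higher number from compound 2 to compound 4 (0.14 log units; within the scatter) and does not separate those two amines. The compounds shown offer no measurement that explains these differences among the amines.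

As far as these compounds go, it remains open whether a six-membered ring amine such as piperidin-1-yl or morpholin-4-yl, or a smaller open-chain amine such as dimethylamino, would match compound 2 and compound 4 or fall closer to compound 3. Also open, from the compounds shown here alone, is whether an amide at this place, with a carbonyl on the same nitrogen, would keep any of the gain over methoxy.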